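Losing a Fluorine on the Outer Ring: What to Expect

This account rests on a few compounds, and the source may have more. Where it says the series, first, only, none or still open, it means among the compounds named here.

Measured in a functional assay on HCT-116 cells (Homo sapiens) for cytotoxicity, read by MTT assay, with a stated time of 48 h; on this read-out lower numbers stand for stronger inhibition and higher numbers for weaker inhibition:
Compound 1, `O=C(CC1c2ccccc2N=C(SCCCCCN2CCCC2)N1c1ccc(-c2ccccc2)cc1)NCc1ccc(F)cc1`, gives 6200 nM.
Compound 2, `CN(C)CCCCCSC1=Nc2ccccc2C(CC(=O)NCc2ccccc2)N1c1ccc(-c2ccccc2)cc1`, gives 9600 nM.
Compound 3, `O=C(CC1c2ccccc2N=C(SCCCCCN2CCCC2)N1c1ccc(-c2ccc(F)cc2)cc1)NCc1ccccc1`, gives 12500 nM.

All three compounds share one core and differ only in their outer parts. On the numbers shown, compound 3 carries the highest value of the three, yet its gap to compound 2 and its gap to compound 1 both fall within the usual scatter of this assay, so the three cannot truly be told apart on this read-out.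

Compound 4, `O=C(CC1c2ccccc2N=C(SCCCCCN2CCCC2)N1c1ccc(-c2ccccc2)cc1)NCc1ccccc1`, differs from compound 3 in a single place: hydrogen in place of fluoro on an aromatic carbon. Put another way, a 4-fluorophenyl becomes a plain phenyl.

Among the compounds with values here, no pair of measured compounds shows exactly this change, so there is no directly comparable step. What the measured set does show is that the changes at the amide end and at the amine end, between compounds 1, 2 and 3, all left values within the scatter of one another. Within the data shown here, with that as the only guide, the loss of one fluoro is expected to give no step beyond the scatter, which is what a 1.4-fold lower number from compound 3 to compound 4 (0.14 log units; within the scatter) expresses. For compound 4 the estimate is 9000 nM, with a range from 4000 nM to 20000 nM.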

Compound 4, half-maximal inhibitory concentration: 5500 nM
Compound 4: middle estimate off by 1.6-fold (0.21 log units), on the high side; the range from low to high includes it.
By their numbers in this assay, from the lowest: compounds 4, 1, 2 and 3 (each within the scatter of the next, the first and the last beyond it).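

In this assay, within the data shown here, hydrogen in place of fluoro on the outer ring gives a 2.3-fold lower number from compound 3 to compound 4 (0.36 log units; beyond the scatter) as a modest step, and this is the first single-place change to clear the scatter. The same exchange at the amide end gives a 1.1-fold lower number from compound 1 to compound 4 (0.05 log units; within the scatter) and pyrrolidin-1-yl in place of dimethylamino gives a 1.7-fold lower number from compound 2 to compound 4 (0.24 log units; within the scatter) with both of these inside the scatter, so the fluoro's effect on this read-out depends on where it sits, at least across these four compounds and on this one pair at each place. Nothing available explains why the 4-fluorophenyl and the plain phenyl differ here.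

Still open, from the compounds shown here alone, is whether other groups at this same place, such as chloro, methyl or methoxy, would stay with the plain phenyl or with the 4-fluorophenyl in this assay. Also open, going by these compounds, is whether the step from 4-fluorophenyl to phenyl would return with dimethylamino at the end of the chain, or with a shorter chain in place of the present one.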